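Shortening a tert-butyl to isopropyl: compound 4 expected unchanged

The source may report more compounds than this note shows. Statements on the series, on what has been measured and on what is new or still open speak of the compounds shown alone.

Measured in an assay on isolated protein for inhibition of proto-oncogene tyrosine-protein kinase receptor Ret (Homo sapiens), read by radiometric assay and 33P incorporation, in the presence of a further agent that is not named here; on this read-out higher numbers stand for weaker inhibition and lower numbers for stronger inhibition:
Compound 1, `CC(C)n1nc(-c2ccon2)c2c(N)ncnc21`: 213 nM
Compound 2, `CC(C)n1nc(-c2cc(C(C)(C)C)on2)c2c(N)ncnc21`: 210 nM
Compound 3, `Nc1ncnc2c1c(-c1cc(C3CC3)on1)nn2C1CCOCC1`: 5 nM

Among these three numbers compound 2 holds the second highest. Its nearest neighbour is compound 1, whose value sits within the scatter of it; its furthest is compound 3, which gives a much lower number, but compound 3 differs from compound 2 in more than one place, so that gap says nothing by itself about any single change.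

Compound 4, `CC(C)c1cc(-c2nn(C(C)C)c3ncnc(N)c23)no1`, differs from compound 2 in one place: hydrogen in place of methyl on a saturated chain carbon bound to an aromatic carbon and two saturated chain carbons. Among the measured compounds shown here, the only measured step that bears on this position is the change from hydrogen to tert-butyl at the same aromatic carbon, a 1.0-fold lower number from compound 1 to compound 2 (0.01 log units; within the scatter), which left the number essentially where it was. Isopropyl sits between hydrogen and tert-butyl in size, and since both ends of that range gave the same reading, no step beyond the scatter is expected in this assay, that is no change at the digits printed from compound 2 to compound 4 (within the scatter). Compound 4 is therefore estimated at 210 nM, with a likely range from 90 nM to 500 nM.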

Compound 4, half-maximal inhibitory concentration: 41 nM
Compound 4: middle estimate off by 5.1-fold (0.71 log units), on the high side, outside the stated range (below it).
By their numbers in this assay, from the lowest: compound 3; then compound 4; then compounds 2 and 1 (each within the scatter of the next).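

In this assay, this aromatic carbon is not indifferent to what it carries, although the earlier pair of compounds, with hydrogen and tert-butyl, gave no sign of that. Hydrogen in place of one methyl, which turns tert-butyl into isopropyl, gives a 5.1-fold lower number from compound 2 to compound 4 (0.71 log units; beyond the scatter), and isopropyl in place of hydrogen gives a 5.2-fold lower number from compound 1 to compound 4 (0.72 log units; beyond the scatter), so the number does not run in order from hydrogen through isopropyl to tert-butyl. No measurement available here explains why isopropyl stands apart from the other two groups.

As far as these compounds go, it remains open whether ethyl, a longer chain or an amine on this carbon would give a number like that of compound 4 or like those of compounds 1 and 2. Compound 3 differs from compound 4 in more than one place, so it cannot show whether the isopropyl step would hold with another group elsewhere on the shared core.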